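The compounds below may be only part of what the source reports. "The series", "measured", "known", "first", "only" and "open" are said of these compounds alone.

Measured in a functional assay on NCI-H1650 cells (Homo sapiens) for cytotoxicity, read by MTT assay, with a stated time of 72 h; a higher number here means a weaker inhibitor, a lower number a stronger inhibitor:

Compound 1 `COC(=O)C(COC(=O)/C=C/c1ccc(OC)c(OC)c1)c1ccccc1`: > 0.01 ug/mL
Compound 2 `CCOC(=O)C(COC(=O)c1ccccc1OC(C)=O)c1ccc(F)cc1`: > 0.01 ug/mL
Compound 3 `CCOC(=O)C(COC(=O)/C=C/c1ccc(OC)c(OC)c1)c1ccc(F)cc1`: > 0.01 ug/mL

None of these three entries is a true half-maximal inhibitory concentration. All of them stop at the same boundary: the limit of > 0.01 ug/mL in this assay, at which 3 of the 3 values shown sit. Compound 2 therefore has no exact place among the three. Its entry, > 0.01 ug/mL, is a limit and not a number. Going by the values given here, the compounds cannot be ranked from these results, and no pair of them differs in only one place, so no measured step shows how large a single change can be.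

Compound 4 `CCOC(=O)C(COC(=O)c1ccccc1OC(C)=O)c1ccc(C(F)(F)F)cc1` has not yet been measured. It keeps the structure of compound 2 except at one site, where trifluoromethyl takes the place of fluoro on an aromatic carbon: trifluoromethyl in place of fluoro on an aromatic carbon. In other words, a 4-fluorophenyl becomes a 4-(trifluoromethyl)phenyl.

Among the compounds with values here, with no measured step to draw on, no shift beyond the usual scatter is expected, in either direction, and another limit is the most likely report. The expected change a step that the limit leaves unreadable from compound 2 to compound 4 is therefore small. For compound 4 the estimated value is 0.012 ug/mL, with an expected range of 0.005 ug/mL to 0.05 ug/mL.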

Compound 4, half-maximal inhibitory concentration: > 0.01 ug/mL
Compound 4: only a limit was reported; the forecaster's own chance of this, stated with the estimate: 85%; the middle value lies beyond the limit too.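

Compound 2 and compound 4 are both reported only as limits, not numbers, so the step between them, from fluoro to trifluoromethyl, cannot be read: the limit of > 0.01 ug/mL in this assay, at which 4 of the 4 values shown sit. The compounds shown leave open how strongly any of them acts in this assay, and whether this exchange of groups changes that at all.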